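Hydantoin to methylated vinyl-linked ring on the shared core

The source may hold more compounds than are shown below. What is called first, only, known or untested is meant among the compounds shown, and "the series" means these compounds.

Compound 1 `CC(C)C(c1ccc(-c2ccc3cccc(F)c3c2)[nH]c1=O)C1NC(=O)NC1=O` is the weakest of the three measured compounds in an assay on membranes from Chem-1 cells for displacement of a labelled ligand from prostaglandin E2 receptor EP3 subtype (Homo sapiens), read by scintillation counting, with a stated time of 2 h (on this read-out higher numbers stand for weaker inhibition and lower numbers for stronger inhibition), giving 50 nM. Compound 2 `CC(C)/C(=C1/SC(=O)NC1=O)c1ccc(-c2ccc3cccc(F)c3c2)[nH]c1=O` gives 22 nM in this assay, and compound 3 `CCn1ncc2c(F)cc(-c3ccc(C(/C=C4\OC(=O)NC4=O)(CC)CC)c(=O)[nH]3)cc21`, on a different core, gives 3 nM; both differences from compound 1 lie beyond the scatter, so compound 1 sits clearly at the high end of the numbers seen so far.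

Compound 4 `CC(C)C(/C=C1/C(=O)NC(=O)N1C)c1ccc(-c2ccc3cccc(F)c3c2)[nH]c1=O` is derived from compound 1 by a single change: a group of 9 heavy atoms (5 carbon, 2 nitrogen, 2 oxygen; one five-membered non-aromatic ring with 2 hetero atoms) in place of a group of 7 heavy atoms (3 carbon, 2 nitrogen, 2 oxygen; one five-membered non-aromatic ring with 2 hetero atoms), on a saturated chain carbon bound to an aromatic carbon and a saturated chain carbon. Within the data shown here, no measured pair isolates this exact step, so its size is unknown. The two measured compounds whose acid-mimic ring is joined through a double bond outside the aromatic system, compound 2 at 22 nM and compound 3 at 3 nM, both sit lower than compound 1, which is the only ground for an expectation here.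

Compound 4 is therefore expected to give a lower number than compound 1, with the step from compound 1 to compound 4 estimated at a 2.5-fold lower number from compound 1 to compound 4 (0.40 log units; beyond the scatter). The value for compound 4 in this assay is estimated at 20 nM, within a range of 6 nM to 70 nM.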

Compound 4, inhibition constant: 6 nM
Estimate against measurement, compound 4: 3.3-fold (0.52 log units) above; measured number inside the range.
By their numbers in this assay, from the lowest: compounds 3 and 4 (each within the scatter of the next); then compound 2; then compound 1.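

Among these compounds, on the saturated chain carbon bound to an aromatic carbon and a saturated chain carbon, replacing 2,5-dioxoimidazolidin-4-yl with the group of 9 heavy atoms gives an 8.3-fold lower number from compound 1 to compound 4 (0.92 log units; beyond the scatter) in this assay, the first step that isolates a change in one place and shows that the read-out responds to the group held at this position. The entering group differs in its heavy-atom count, its double bonds outside aromatic rings and its hydrogen-bond donors, and this single step cannot assign the lower number to any one of these features. No measurement at hand accounts for the size of the step.

Still open, as far as these compounds go, is whether the ring methyl or the double-bonded link carries the step. Also open, from the compounds shown here alone, is how a carboxylic acid or an amine at this place would read out on the shared core.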